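Difluoropiperidinyl in Place of Pyrazolyl on Compound 1

The source may report more compounds than this note shows. Statements on the series, on what has been measured and on what is new or still open speak of the compounds shown alone.

Compound 1 `C[C@@H]1CN(c2sc(C(F)(F)F)nc2-c2nc3ccccc3[nH]2)CCN1C(=O)Cn1cccn1` gives 191 nM in a functional assay on Venous blood for antagonist activity at C-X-C chemokine receptor type 3 (Homo sapiens), read by flow cytometry, with a stated time of 30 min, in the presence of a further agent that is not named here (on this read-out higher numbers stand for weaker inhibition and lower numbers for stronger inhibition), the smallest of the three numbers in hand, though compound 3 `Cc1nc(C)n(CC(=O)N2CCN(c3sc(C(F)(F)F)nc3-c3nc4c(F)cccc4[nH]3)C[C@H]2C)n1` at 321 nM and compound 2 `Cc1nc(C)n(CC(=O)N2CCN(c3sc(C(F)(F)F)nc3-c3nc4cccc(C)c4[nH]3)C[C@H]2C)n1` at 376 nM both lie within the scatter of it, so no order among them is claimed. Among the compounds with values here, the one measured step, a 1.2-fold lower number from compound 2 to compound 3 (0.07 log units; within the scatter), touches a different part of the shared core and does not bear on compound 4 `C[C@@H]1CN(c2sc(C(F)(F)F)nc2-c2nc3ccccc3[nH]2)CCN1C(=O)CN1CCC(F)(F)CC1`, which differs from compound 1 thus: 4,4-difluoropiperidin-1-yl in place of 1H-pyrazol-1-yl on a saturated chain carbon bound to a carbonyl carbon. Within the data shown here, no measured step alters this part of the molecule, so nothing here points to a direction, and the expectation is a step of a 1.3-fold higher number from compound 1 to compound 4 (0.12 log units; within the scatter) of no size beyond the scatter. Compound 4 is therefore estimated at 250 nM, ranging from 80 nM to 800 nM.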

Compound 4, half-maximal inhibitory concentration: 2430 nM
For compound 4 the middle estimate is 9.7-fold (0.99 log units) below the measured one; the measured number lies above the stated range.
By their numbers in this assay, from the lowest: compounds 1, 3 and 2 (each within the scatter of the next); then compound 4.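

In this assay, within the data shown here, the change to 4,4-difluoropiperidin-1-yl in place of 1H-pyrazol-1-yl brings a 13-fold higher number from compound 1 to compound 4 (1.10 log units; beyond the scatter) and is the only step here beyond the scatter. Among these compounds, the group on this saturated chain carbon bound to a carbonyl carbon therefore matters for this read-out, something the earlier compounds could not show, as none of them varied it. Nothing at hand accounts for the size of the step. Still open, from the compounds shown here alone, is whether the change follows the piperidine ring or its two fluorines, which plain piperidin-1-yl would separate. Also open, going by these compounds, is whether an imidazol-1-yl or morpholin-4-yl group here would behave like the pyrazolyl group.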